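The source may hold more compounds than are shown below. What is called first, only, known or untested is meant among the compounds shown, and "the series" means these compounds.

Four compounds built on one shared core are considered here, differing only in the aryl groups at their two ends. Compound 1 `Cc1ccccc1Nc1nc(C)c(C(=O)/C=C/c2ccc(Cl)cc2)s1`, compound 2 `Cc1ccc(Nc2nc(C)c(C(=O)/C=C/c3ccc(Cl)cc3)s2)cc1` and compound 3 `Cc1ccc(Nc2nc(C)c(C(=O)/C=C/c3ccccc3Cl)s2)cc1` have been tested in a functional assay on Bel-7402 cells (Homo sapiens) for cytotoxicity, read by MTT assay; on this read-out higher numbers stand for weaker inhibition and lower numbers for stronger inhibition. In this assay compound 1 reaches only the limit of > 25000 nM. Compound 2 likewise gives no number in this assay but only the limit of > 25000 nM. For compound 3 this assay again reports only the limit of > 25000 nM.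

The change from compound 2 to compound 1 is 2-methylphenyl in place of 4-methylphenyl on a nitrogen on an aromatic ring. Its size cannot be told, since the step that the two limits leave unreadable from compound 2 to compound 1 is hidden by the limit of > 25000 nM in this assay, at which 3 of the 3 values shown sit. The cores of compound 3 and compound 2 differ by 2-chlorophenyl in place of 4-chlorophenyl on a double-bonded chain carbon bound to a double-bonded chain carbon, and the step that the two limits leave unreadable from compound 2 to compound 3 is unreadable for the same reason.

Compound 4 `Cc1ccccc1Nc1nc(C)c(C(=O)/C=C/c2ccccc2Cl)s1` has not yet been measured in this assay. It stands to compound 3 as compound 1 stands to compound 2, through (2-methylphenyl in place of 4-methylphenyl on a nitrogen on an aromatic ring), the same change at the same place. With the earlier step unsized, the step from compound 3 to compound 4 is estimated at a number no higher from compound 3 to compound 4 (the limit leaves the size open). Compound 4 is expected to give 25000 nM in this assay, most probably again as a limit rather than a number, with an estimated range from 10000 nM to 60000 nM.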

Compound 4, half-maximal inhibitory concentration: > 25000 nM
Compound 4: no number, only a limit; the forecaster's own chance of this, stated with the estimate: 85%; the middle value lies on the limit itself.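

Compound 4 again gives only a limit in this assay, so neither its step from compound 3 nor its step from compound 1 can be read, and no new step follows: the limit of > 25000 nM in this assay, at which 4 of the 4 values shown sit.

The four compounds shown leave open how large either change, 2-methylphenyl in place of 4-methylphenyl or 2-chlorophenyl in place of 4-chlorophenyl, is in this assay, and whether the two changes add up when combined.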